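The source may hold more compounds than are shown below. What is called first, only, known or untested is meant among the compounds shown, and "the series" means these compounds.

Of the compounds shown here, three share one core and have been tested in a functional assay on Ramos cells (Homo sapiens) for antiproliferative activity, read by CCK-8 assay, with a stated time of 72 h, tested at 40 uM; on this read-out higher numbers stand for more inhibition at the one concentration tested (going by the name of the read-out) and lower numbers for less inhibition. Compound 1 `CN1CCN(c2ccc(Nc3nc(-c4cccc(NC(=O)c5ccc(Cl)cc5)c4)sc3C(=O)O)cc2)CC1` gives 71.6%. Compound 2 `CN1CCN(c2ccc(Nc3nc(-c4cccc(NC(=O)c5ccc(C(C)(C)C)cc5)c4)sc3C(N)=O)cc2)CC1` gives 80.1%, and compound 3 `CN1CCN(c2ccc(Nc3nc(-c4cccc(NC(=O)c5ccccc5)c4)sc3C(N)=O)cc2)CC1` gives 98.1%, the highest of the three numbers, lying beyond the scatter above both compound 2 and compound 1. One measured step joins two compounds that differ in a single place: a number 18 percentage points higher from compound 2 to compound 3 (beyond the scatter). Compound 4 `CN1CCN(c2ccc(Nc3nc(-c4cccc(NC(=O)c5ccc(Cl)cc5)c4)sc3C(N)=O)cc2)CC1` is the next step from compound 3: chloro in place of hydrogen on an aromatic carbon. The step from compound 2 to compound 3 is the only measured one that bears on this change, and it shows that exchanging a group at this same aromatic carbon moved the number by a modest amount, with the bare hydrogen giving the higher value. Compound 1 carries the same chloro but also a carboxylic acid in place of the amide, so its lower number hints only loosely at the same direction. A modest drop is therefore expected. Compound 4 is expected to give 84%, within 66% to 98%, a step of a number 14.1 percentage points lower from compound 3 to compound 4 (beyond the scatter).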

Compound 4, a percentage reported as inhibition, at one concentration (the size of the read-out at that concentration, not a potency): 99%
The estimate for compound 4 lay 15 percentage points below the measured number, and the stated range ends below it.
By their numbers in this assay, from the lowest: compounds 1 and 2 (each within the scatter of the next); then compounds 3 and 4 (each within the scatter of the next).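

At this aromatic carbon, chloro in place of hydrogen changes little in this assay, with a number 0.9 percentage points higher from compound 3 to compound 4 (within the scatter), so the higher number of compound 3 over compound 2 does not mean that any group here lowers the read-out: chloro in place of tert-butyl gives a number 18.9 percentage points higher from compound 2 to compound 4 (beyond the scatter) and the two substituents are clearly not equivalent. Compound 4 also forms a clean pair with compound 1, and amino in place of hydroxy on the carbonyl carbon gives a number 27.4 percentage points higher from compound 1 to compound 4 (beyond the scatter), which places that gap at the carboxylic acid rather than at the chloro. No measurement at hand gives a reason for these steps.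

Going by these compounds, whether a fluoro, a methoxy or a dimethylamino group at this aromatic carbon would behave like chloro or like tert-butyl stays open, as does the effect of a methyl ester on the carbonyl carbon. A read-out at one concentration also cannot show whether compound 3 and compound 4 differ in potency.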